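The compounds below may be only part of what the source reports. "The series", "measured", "known", "first", "only" and "open" are said of these compounds alone.

Within the data shown here, compound 2 `O=C(NCc1ccc(S(=O)(=O)c2cc(F)cc(F)c2)cc1)c1cc2cnccc2[nH]1` gives 63% in an ADME assay on microsomes from liver (Mus musculus) for metabolic stability, read by LC-MS, with a stated time of 30 min, tested at 1 uM (a lower number here means that less of the compound is left, a higher number that more of the compound is left), the highest of the three numbers measured so far. Compound 1 `O=C(NCc1ccc(S(=O)(=O)c2cc(F)cc(F)c2)cc1)c1cc2ccncc2o1` gives 12%, and compound 3 `O=C(NCc1ccc(S(=O)(=O)c2ccccc2)cc1)c1ccc2nncn2c1` gives 47%. Among the measured compounds shown here, the only measured step, a number 51 percentage points higher from compound 1 to compound 2 (beyond the scatter), concerns the group on the carbonyl carbon and leaves the sulfonyl side untouched. Compound 4 `O=C(NCc1ccc(S(=O)(=O)c2cccc(C(F)(F)F)c2)cc1)c1cc2cnccc2[nH]1` differs from compound 2 on that sulfonyl side alone: 3-(trifluoromethyl)phenyl in place of 3,5-difluorophenyl on a sulfonyl sulfur. For the measured compounds named here, no measured step speaks to this change, so no shift beyond the scatter is expected in this assay. For compound 4 this means an expected step of a number 8 percentage points lower from compound 2 to compound 4 (within the scatter) from compound 2. The estimated value for compound 4 is 55%, with a range from 35% to 75%.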

Compound 4, percent of the compound remaining: 49%
The estimate for compound 4 lay 6 percentage points above the measured number; the range from low to high includes it.
By their numbers in this assay, from the lowest: compound 1; then compounds 3 and 4 (each within the scatter of the next); then compound 2.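

The sulfonyl side is not neutral in this assay: 3-(trifluoromethyl)phenyl in place of 3,5-difluorophenyl on a sulfonyl sulfur gives a number 14 percentage points lower from compound 2 to compound 4 (beyond the scatter). Among these compounds, until now, the only measured step lay on the carbonyl carbon, and at a number 51 percentage points higher from compound 1 to compound 2 (beyond the scatter) it remains the larger of the two. Nothing measured here accounts for the new step. Still open, as far as these compounds go, is how a morpholine or a cyclopropyl on the sulfonyl sulfur would fare, and whether the same change would give a similar step on the core of compound 1.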